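Swapping Chloro for Bromo on Two Related Cores

This account rests on a few compounds, and the source may have more. Where it says the series, first, only, none or still open, it means among the compounds named here.

Compound 1, `NC(=S)N/N=C1/C(=O)N(CN2CCN(c3ccnc4cc(Cl)ccc34)CC2)c2cccc(Cl)c21`, gives 19800 nM in an ADME assay on MCF-10A cells (Homo sapiens) for cytotoxicity, read by sulforhodamine B assay, with a stated time of 48 h; a lower number here means a stronger inhibitor of growth, a higher number a weaker inhibitor of growth.
Compound 2, `NC(=S)N/N=C1/C(=O)N(CN2CCN(c3ccnc4cc(Cl)ccc34)CC2)c2cccc(Br)c21`, gives 29400 nM in this assay.
Compound 3, `NC(=S)N/N=C1\C(=O)Nc2cc(Cl)ccc21`, gives 48500 nM in this assay.

Compounds 1 and 2 share one core; compound 3 and the unmeasured compound 4, `NC(=S)N/N=C1\C(=O)Nc2cc(Br)ccc21`, share another. The difference between the two cores is not broken down here. Going from compound 1 to compound 2 the change is bromo in place of chloro on an aromatic carbon, and it moved the number by a 1.5-fold higher number from compound 1 to compound 2 (0.17 log units; within the scatter). From compound 3 to compound 4 the change is bromo in place of chloro on an aromatic carbon. This is the same kind of change, though the place differs: in the first pair the carbon is ortho to a fused ring and meta to a fused ring, in the second it is meta to a fused ring and para to a fused ring. Because the earlier step of a 1.5-fold higher number from compound 1 to compound 2 (0.17 log units; within the scatter) stayed within the scatter, a step of similar size, a 1.3-fold higher number from compound 3 to compound 4 (0.13 log units; within the scatter), is expected here. Compound 4 is therefore estimated at 65000 nM, between 30000 nM and 140000 nM.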

Compound 4, concentration for 50% growth inhibition: 32000 nM
For compound 4 the middle estimate is 2.0-fold (0.31 log units) above the measured one, and the stated range covers the measured number.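

In this assay, bromo in place of chloro on an aromatic carbon gives a 1.5-fold lower number from compound 3 to compound 4 (0.18 log units; within the scatter), so on this core too the swap stays within the usual scatter. Set beside the same swap on the core of compound 1, the two steps do not differ by more than scatter allows: the same change on two cores in this assay, a 1.5-fold higher number (0.17 log units; within the scatter) from compound 1 to compound 2 and a 1.5-fold lower number (0.18 log units; within the scatter) from compound 3 to compound 4, 2.3-fold (0.35 log units) apart, within the scatter of two such steps. This shows that, across these two pairs, the swap makes no clear difference on either core, but two small steps at different places on the ring cannot show a rule for the series.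

Still open, going by these compounds, is whether a different group on that aromatic carbon, such as fluoro, methoxy or an amine, would move the number beyond the scatter, and whether it would do so equally on both cores.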